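Second fluoro on the hydroxyphenyl ring of compound 3

This account rests on a few compounds, and the source may have more. Where it says the series, first, only, none or still open, it means among the compounds named here.

Of the compounds shown here, three have been measured in an assay on isolated protein for inhibition of protein kinase C iota type (Homo sapiens), tested at 20 uM; a lower number here means less inhibition, a higher number more inhibition at the concentration tested (going by the name of the read-out). Compound 1 `Nc1ccc(C2=NN(c3ccc(Cl)cc3)C(c3ccc(O)cc3)C2)cc1` gives 38.7%. Compound 2 `CC(C)(C)C1=NN(c2ccc(Cl)cc2)C(c2ccc(O)c(F)c2)C1` gives 29.7%. Compound 3 `Oc1ccc(C2CC(c3ccccc3O)=NN2c2cccc(Cl)c2)cc1F` gives 25.2%, the lowest of the three numbers; its gap to compound 2 lies within the scatter, so no order can be read between these two, while its gap to compound 1 lies beyond the scatter, with compound 1 the higher of that pair.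

Compound 4 `Oc1ccccc1C1=NN(c2cccc(Cl)c2)C(c2cc(F)c(O)c(F)c2)C1` has not yet been measured. It differs from compound 3 in one place: fluoro in place of hydrogen on an aromatic carbon. Cut one bond further out, the change reads 3-fluoro-4-hydroxyphenyl to 3,5-difluoro-4-hydroxyphenyl, the fluoro entering ortho to the hydroxy group and meta to the fluoro already present.

For the measured compounds named here, no step between measured compounds isolates this kind of change, so there is no precedent for its size or direction. A single fluorine added to an already fluorinated ring is a small alteration; the expectation is for a step from compound 3 of about a number 0.8 percentage points higher from compound 3 to compound 4 (within the scatter), that is, none beyond the scatter, in either direction. On that basis compound 4 is estimated to give 26% in this assay, within a range of 12% to 40%.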

Compound 4, a percentage reported as inhibition, at one concentration (the size of the read-out at that concentration, not a potency): 45.2%
Compound 4: middle estimate off by 19.2 percentage points, on the low side, outside the stated range (above it).
By their numbers in this assay, from the lowest: compounds 3, 2, 1 and 4 (each within the scatter of the next, the first and the last beyond it).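

In this assay, for the compounds shown here, the change from 3-fluoro-4-hydroxyphenyl to 3,5-difluoro-4-hydroxyphenyl gives a number 20 percentage points higher from compound 3 to compound 4 (beyond the scatter), the first step that isolates a single place. The aromatic carbon ortho to a hydroxy group and meta to a fluoro group is therefore not a silent position in this background: one fluoro in place of hydrogen, a single heavy atom, is enough to move the read-out beyond the scatter. Nothing measured on these compounds accounts for the step, so its origin stays unassigned.

Open, from the compounds shown here alone, is whether the step belongs to fluoro specifically or would also appear with chloro, methyl, methoxy or an amine on the same carbon, and whether removing the fluoro already present, leaving only the new one, would keep it. Also open, going by these compounds, is whether the same change on compound 2, which carries the 3-fluoro-4-hydroxyphenyl group as well but differs elsewhere, would give a step of similar size and direction, or whether this one holds only alongside the other groups of compound 3.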